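The source may hold more compounds than are shown below. What is called first, only, known or untested is meant among the compounds shown, and "the series" means these compounds.

The measured compounds in this series:

compound 1, `Nc1ccccc1-c1cnc(C(=O)CCCCCCc2ccccc2)o1`: 750 nM
compound 2, `N#Cc1ccc(-c2cnc(C(=O)CCCCCCc3ccccc3)o2)cc1`: 40 nM
compound 3, `O=C(CCCCCCc1ccccc1)c1ncc(I)o1`: 3 nM

In an assay (Rattus norvegicus) for inhibition of Fatty-acid amide hydrolase 1 (Homo sapiens) (on this read-out higher numbers stand for weaker inhibition and lower numbers for stronger inhibition), compound 3 gives the lowest number of the three. Both measured steps leading to it are large: a 250-fold lower number from compound 1 to compound 3 (2.40 log units; beyond the scatter) and a 13-fold lower number from compound 2 to compound 3 (1.12 log units; beyond the scatter), each beyond the scatter. The step between the two aryl-bearing compounds, a 19-fold lower number from compound 1 to compound 2 (1.27 log units; beyond the scatter), is large as well, so all three compounds stand clearly apart from one another.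

Compound 4, `O=C(CCCCCCc1ccccc1)c1ncc(F)o1`, is reached from compound 3 by a single exchange: fluoro in place of iodo on an aromatic carbon. Going by the values given here, none of the measured steps involves fluorine; each of them replaces an aryl group at this carbon with another aryl group or with iodine. They show only that iodine at this position gives a lower number than either aryl group, and say nothing direct about a second, smaller halogen there. Among the compounds with values here, with no measured step bearing on the iodo-to-fluoro exchange, the expectation is based on the general observation that substituent identity at this carbon moves the read-out strongly. Compound 4 is therefore expected to show a 6.7-fold higher number from compound 3 to compound 4 (0.82 log units; beyond the scatter), a number higher than compound 3, with wide uncertainty. The estimate for compound 4 is 20 nM, in a range from 4 nM to 100 nM.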

Compound 4, inhibition constant: 30 nM
For compound 4 the middle estimate is 1.5-fold (0.18 log units) below the measured one, and the stated range covers the measured number.
By their numbers in this assay, from the lowest: compound 3; then compounds 4 and 2 (each within the scatter of the next); then compound 1.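

Read in this assay, the exchange of one halogen for another at this carbon next to the ring oxygen is not neutral: a 10-fold higher number from compound 3 to compound 4 (1.00 log units; beyond the scatter) is a step beyond the scatter, so the low number of compound 3 belongs to iodo in particular and not to just any halogen there. Fluoro also gives up nearly all of the advantage that iodo held over the aryl groups, since a 1.3-fold lower number from compound 2 to compound 4 (0.12 log units; within the scatter) places compound 4 within the scatter of the 4-cyanophenyl compound, while a 25-fold lower number from compound 1 to compound 4 (1.40 log units; beyond the scatter) still sets it clearly apart from the 2-aminophenyl compound. No measurement presented here accounts for the gap between the two halogens.

The compounds shown leave open whether chloro or bromo at this carbon would fall between fluoro and iodo, or whether the numbers of a halogen series would follow no such order, and where a plain hydrogen at this carbon would stand against them. They also leave open whether the gap between iodo and fluoro would persist with a longer chain on the carbonyl.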